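Lengthening the alkyl chain: from compound 2 to compound 3

This account rests on a few compounds, and the source may have more. Where it says the series, first, only, none or still open, it means among the compounds named here.

Measured so far:
compound 1 `CCc1ccc(NC(=O)N[C@H](C)c2ccccc2)cc1` — 47%
compound 2 `CCCc1ccc(NC(=O)N[C@H](C)c2ccccc2)cc1` — 31%

In an ADME assay on the whole organism with Oryza sativa as the target, tested at 1 uM (a higher number here means a weaker effect of the compound at the concentration tested, a lower number a stronger effect), compound 1 gives 47% and compound 2 gives 31%. Compound 2 stands lowest of the two numbers; its nearest neighbour is compound 1. Going by the values given here, the only measured step, a number 16 percentage points lower from compound 1 to compound 2 (beyond the scatter), is beyond the scatter and modest in size.

Compound 3 `CCCCc1ccc(NC(=O)N[C@H](C)c2ccccc2)cc1` differs from compound 2 by methyl in place of hydrogen on a saturated chain carbon, three bonds along the chain from an aromatic carbon. Among the compounds with values here, this is the same kind of change as the measured step, cut one bond further out, so a number 16 percentage points lower from compound 1 to compound 2 (beyond the scatter) is the one step that bears on it. On that basis a further downward step in this assay is expected, of comparable or somewhat smaller size, though a single step is a thin basis. Compound 3 is therefore estimated at 20%, with a range from 6% to 36%. The expected step is a number 11 percentage points lower from compound 2 to compound 3 (beyond the scatter).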

Compound 3, a percentage reported as activity, at one concentration (the size of the read-out at that concentration, not a potency): 32%
The estimate for compound 3 lay 12 percentage points below the measured number; the range from low to high includes it.
By their numbers in this assay, from the lowest: compounds 2 and 3 (each within the scatter of the next); then compound 1.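

In this assay, going from propyl to butyl gives a number 1 percentage points higher from compound 2 to compound 3 (within the scatter), so compound 2 and compound 3 cannot be told apart and the downward step seen from ethyl to propyl has no measurable continuation at this place. Going by these compounds alone, measured against the ethyl chain, butyl still gives a number 15 percentage points lower from compound 1 to compound 3 (beyond the scatter), so over these three chains the only step beyond the scatter is the one that separates ethyl from the two longer chains. Nothing measured in this series speaks to the reason for this plateau.

The compounds shown leave open whether a longer chain such as pentyl or hexyl would stay on this plateau or move away from it in this assay. They also leave open how a branched chain such as isobutyl, or an amine or a hydroxyl at the end of the chain, would read.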